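The source may hold more compounds than are shown below. What is called first, only, known or untested is meant among the compounds shown, and "the series" means these compounds.

Of the compounds shown here, two have been measured in an assay on Jurkat cells for displacement of a labelled ligand from C-X-C chemokine receptor type 4 (Homo sapiens), tested at 10 uM (a higher number here means more inhibition at the concentration tested (going by the name of the read-out), a lower number less inhibition), so far. Compound 1 `C[C@@H](NC(=O)[C@H](CCCNC(=N)N)NC(=O)c1ccc(CN(Cc2ccncc2)C(=O)c2ccc(F)cc2)cc1)c1cccc2ccccc12` gives 6% in this assay, and compound 2 `C[C@H](NC(=O)[C@H](CCCNC(=N)N)NC(=O)c1ccc(CN(Cc2cccnc2)C(=O)c2ccc(F)cc2)cc1)c1cccc2ccccc12` gives 14%. Compound 2 holds the higher of the two numbers, but the gap to compound 1 lies within the usual scatter of this assay, so the two results cannot be told apart; both show only weak displacement at the concentration tested.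

Compound 3 `C[C@H](NC(=O)[C@H](CCCNC(=N)N)NC(=O)c1ccc(CN(Cc2ccncc2)C(=O)c2ccc(F)cc2)cc1)c1cccc2ccccc12` is built from compound 2 by a single rearrangement: pyridin-4-yl in place of pyridin-3-yl on a saturated chain carbon bound to an amide-type nitrogen. The two compounds contain the same atoms, joined differently. Going by the values given here, no measured pair in this set isolates this change, so there is no direct precedent to lean on.

Given that both measured compounds sit low, the step from compound 2 to compound 3 is expected to be small, with no change beyond the scatter, giving a number 4 percentage points lower from compound 2 to compound 3 (within the scatter). Compound 3 is therefore estimated at 10% in this assay, within a range of 0% to 25%.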

Compound 3, a percentage reported as inhibition, at one concentration (the size of the read-out at that concentration, not a potency): 13%
Compound 3: middle estimate off by 3 percentage points, on the low side; measured number inside the range.
By their numbers in this assay, from the lowest: compounds 1, 3 and 2 (each within the scatter of the next).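

In this assay, putting pyridin-4-yl in place of pyridin-3-yl on a saturated chain carbon bound to an amide-type nitrogen gives a number 1 percentage points lower from compound 2 to compound 3 (within the scatter), so this change of ring shows no readable effect at this position. With pyridin-4-yl held fixed, changing the drawn configuration at a saturated chain carbon gives a number 7 percentage points higher from compound 1 to compound 3 (within the scatter), so stereochemistry at that carbon shows no readable effect either. This pair is the only comparison shown that isolates a stereo difference: the fact that one of compounds 1 and 3 is drawn with a defined configuration and the other without, at the place where they differ

Going by these compounds, what pyridin-2-yl or an unsubstituted phenyl ring would do at this position remains open. On these data alone, with all three compounds showing only weak displacement, it also remains open whether either change would matter on a compound that displaces the ligand more strongly.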